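The compounds below may be only part of what the source reports. "The series", "measured", "known", "first", "only" and "open" are said of these compounds alone.

In an ADME assay on MDBK cells (Bos taurus) for cytotoxicity (on this read-out lower numbers stand for higher toxicity in this test and higher numbers for lower toxicity in this test), the measured compounds stand as follows:

Compound 1 `Fc1cccc(F)c1Cn1c(-c2c(F)cccc2F)nc2cnccc21` gives > 100000 nM, which is a limit of the assay and not a number.
Compound 2 `Fc1cccc(F)c1-c1nc2ccn(Cc3ccccc3)cc-2n1` gives > 100000 nM, again a limit of the assay.
Compound 3 `Fc1ccccc1Cn1ccc2nc(-c3ccccc3)nc-2c1` gives > 100000 nM, also a limit of the assay.

Compound 3 therefore stands at the limit shared by every value shown here, since (the limit of > 100000 nM in this assay, at which 3 of the 3 values shown sit). Going by the values given here, no step between two measured compounds is available, so no measured difference can guide the next change. Compound 4 `Clc1ccc(Cn2ccc3nc(-c4ccccc4)nc-3c2)cc1Cl` differs from compound 3 by 3,4-dichlorophenyl in place of 2-fluorophenyl on a saturated chain carbon bound to an aromatic nitrogen. In this assay the step of a number no higher from compound 3 to compound 4 (the limit leaves the size open) is expected to stay within the scatter, with a limit the likeliest outcome once more. Compound 4 is thus estimated at 100000 nM, between 30000 nM and 300000 nM.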

Compound 4, half-maximal cytotoxic concentration: 71000 nM
Compound 4: the middle estimate sits 1.4-fold (0.15 log units) above what was measured, within the range that was stated.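

In this assay, compound 4, with 3,4-dichlorophenyl in place of 2-fluorophenyl on a saturated chain carbon bound to an aromatic nitrogen, gives a number and not a limit. As far as these compounds go, the change is read as an at least 1.4-fold lower number from compound 3 to compound 4 (0.14 log units; that floor lies within the scatter), so the true size of the step stays open, and this floor does not show that the two compounds differ. Most readings still give no number: the limit of > 100000 nM in this assay, at which 3 of the 4 values shown sit.

The compounds shown leave open what a single chlorine would give at this position. They also leave open how an amine or a carboxylic acid in place of the phenyl ring would read.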